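Swapping Sulfur for Selenium on a Shared Core

The source may report more compounds than this note shows. Statements on the series, on what has been measured and on what is new or still open speak of the compounds shown alone.

Of the compounds shown here, two on the same core have been measured so far. Compound 1, `OCC#CCSc1cnc2ccccc2c1SCC#CCCl`, carries two chains on the core. In a functional assay on P388 cells (Mus musculus) for antiproliferative activity, with a stated time of 72 h (on this read-out higher numbers stand for weaker inhibition and lower numbers for stronger inhibition), compound 1 gives 5.1 ug/mL. Compound 2, `CSc1cnc2ccccc2c1[Se]CC#CCOC(=O)c1ccccc1`, carries a selenium-linked chain capped with a benzoate ester, and in this assay compound 2 gives 3.5 ug/mL. Compound 1 holds the higher of these two numbers, but the gap to compound 2 is within the scatter of repeated measurements, so the two cannot be told apart.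

Compound 3, `OCC#CCSc1cnc2ccccc2c1[Se]CC#CCCl`, has not yet been measured. It differs from compound 1 in one place: a group of 6 heavy atoms (4 carbon, 1 chlorine, 1 selenium; no ring) in place of a group of 6 heavy atoms (4 carbon, 1 sulfur, 1 chlorine; no ring), on an aromatic carbon. Sulfur gives way to selenium while everything else is kept. Within the data shown here, no measured pair isolates such a change, so there is no measured step to lean on. Because compound 2 gives 3.5 ug/mL in this assay, a selenium-bearing compound has already given a number in this range. The step is expected to be small, a 1.3-fold lower number from compound 1 to compound 3 (0.11 log units; within the scatter), with no direction beyond the scatter. Compound 3 is therefore estimated at 4 ug/mL, within a range from 1.5 ug/mL to 10 ug/mL.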

Compound 3, concentration for 50% inhibition: 2 ug/mL
Estimate against measurement, compound 3: 2.0-fold (0.30 log units) above; low and high end bracket the measured number.
By their numbers in this assay, from the lowest: compounds 3, 2 and 1 (each within the scatter of the next, the first and the last beyond it).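

In this assay, exchanging sulfur for selenium in the chain on the aromatic carbon opposite the ring nitrogen gives a 2.6-fold lower number from compound 1 to compound 3 (0.41 log units; beyond the scatter). Among these compounds, this pair is the first to isolate that exchange, and it shows that changing only the atom linking this chain to the core can move the number beyond the scatter, although the step is modest. The two earlier compounds differ in more than one place and could not show this. No measurement here accounts for the lower number with selenium, so the reason for the step remains unknown.

This single pair leaves open whether the same exchange would give a similar step in the other sulfur-linked chain on the shared core, or with the benzoate ester chain of compound 2 in place of the chlorine-bearing chain. It also leaves open how an oxygen or amine link would compare at this position, and what would happen with an amine in place of the chlorine or with a longer chain.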